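Adding a Second Chloro to a Bicyclic Chloro Core

The source may report more compounds than this note shows. Statements on the series, on what has been measured and on what is new or still open speak of the compounds shown alone.

Compound 1 `ClCc1ccc(Cn2cnc3c(Cl)ncnc32)cc1` carries one chloro group on its fused two-ring core; in a functional assay on SNB-75 cells (Homo sapiens) for cytotoxicity, read by sulforhodamine B assay, with a stated time of 48 h (on this read-out higher numbers stand for weaker inhibition of growth and lower numbers for stronger inhibition of growth), compound 1 gives "not determined" (no result reported), so it stands nowhere on the scale yet. Compound 2 `ClCc1ccc(Cn2cnc3nc(Cl)nc(Cl)c32)cc1` carries two chloro groups and in this assay gives 2080 nM. Compound 3 `ClCc1ccc(Cn2cnc3c(Cl)nc(Cl)nc32)cc1` differs from compound 1 by chloro in place of hydrogen on an aromatic carbon. Because compound 2, which also bears two chloro groups, gives 2080 nM in this assay, compound 3 is expected to land near that level, at about 2500 nM, with a likely range from 800 nM to 8000 nM.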

Compound 3, concentration for 50% growth inhibition: 3160 nM
Beside the measured number, compound 3's estimate is 1.3-fold (0.10 log units) below it, and the stated range covers the measured number.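

Going by these compounds alone, compound 1 gives "not determined" (no result reported), so no step from it to compound 3 can be read. What the added chloro does to growth inhibition stays open, and nothing here points to a cause.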